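Swapping a Pivalate for a Toluate on the Shared Core

The source may hold more compounds than are shown below. What is called first, only, known or untested is meant among the compounds shown, and "the series" means these compounds.

Compound 1 `C=C1[C@H](OC(C)=O)[C@@H](OC(C)=O)[C@@H](OC(C)=O)C(C)(C)/C=C/[C@H](C)[C@H](OC(=O)c2ccccc2)[C@@]2(O)C[C@@](C)(O)[C@H](OC(C)=O)[C@@H]2[C@H]1OCC(C)C` in a functional assay on NCI/ADR-RES cells (Homo sapiens) for positive allosteric modulation, read by MTT assay, with a stated time of 48 h, tested at 10 uM (on this read-out lower numbers stand for stronger inhibition and higher numbers for weaker inhibition), gives 13000 nM.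
Compound 2 `C=C1[C@H](OC(C)=O)[C@@H](OC(=O)C(C)(C)C)[C@@H](OC(C)=O)C(C)(C)/C=C/[C@H](C)[C@H](OC(=O)c2ccccc2)[C@@]2(O)C[C@@](C)(O)[C@H](OC(C)=O)[C@@H]2[C@H]1OCC(C)C` in this assay gives 1220 nM.
Compound 3 `C=C1[C@H](OC(C)=O)[C@@H](OC(=O)C(C)(C)C)[C@@H](OC(C)=O)C(C)(C)/C=C/[C@H](C)[C@H](OC(=O)c2ccccc2)[C@@]2(O)C[C@@](C)(OC(C)=O)[C@H](OC(C)=O)[C@@H]2[C@H]1OCC(C)C` in this assay gives 1730 nM.

Compound 3 stands second highest of these three numbers; its nearest neighbour is compound 2, and the step of a 1.4-fold higher number from compound 2 to compound 3 (0.15 log units; within the scatter) lies within the scatter, whereas compound 1 sits far above both. Compound 4 `C=C1[C@H](OC(C)=O)[C@@H](OC(=O)c2cccc(C)c2)[C@@H](OC(C)=O)C(C)(C)/C=C/[C@H](C)[C@H](OC(=O)c2ccccc2)[C@@]2(O)C[C@@](C)(OC(C)=O)[C@H](OC(C)=O)[C@@H]2[C@H]1OCC(C)C` differs from compound 3 in one place: 3-methylphenyl in place of tert-butyl on a carbonyl carbon. For the measured compounds named here, no measured step exchanges an acyl group for an aromatic one, so there is no direct precedent. The closest guide is an 11-fold lower number from compound 1 to compound 2 (1.03 log units; beyond the scatter), which shows that the group on this carbonyl carbon can move the number a great deal, while a 1.4-fold higher number from compound 2 to compound 3 (0.15 log units; within the scatter) was small. A result close to the current level, with wide uncertainty, is expected. Compound 4 is estimated at 1500 nM, between 400 nM and 6000 nM, an expected step of a 1.2-fold lower number from compound 3 to compound 4 (0.06 log units; within the scatter) in this assay.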

Compound 4, half-maximal inhibitory concentration: 1920 nM
Estimate against measurement, compound 4: 1.3-fold (0.11 log units) below; the measured number falls inside the stated range.
By their numbers in this assay, from the lowest: compounds 2, 3 and 4 (each within the scatter of the next); then compound 1.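

In this assay, putting 3-methylphenyl in place of tert-butyl on this carbonyl carbon gives a 1.1-fold higher number from compound 3 to compound 4 (0.05 log units; within the scatter), so an aromatic ring can replace this branched group without a change beyond the scatter. For the compounds shown here, the large 11-fold lower number from compound 1 to compound 2 (1.03 log units; beyond the scatter) showed that this position can respond strongly, yet this new pair shows that tert-butyl is not the only group compatible with a number at this level. Nothing available explains why these two groups read alike.

On these data alone, it remains open how a plain phenyl, a longer chain or a carboxylic acid would read on this carbonyl carbon.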